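The source may hold more compounds than are shown below. What is called first, only, known or untested is meant among the compounds shown, and "the series" means these compounds.

Compound 1 `COc1cc(C(=O)c2cn(-c3cccc(Cl)c3)cc2-c2ccccc2)cc(OC)c1OC`: 150 nM
Compound 2 `COc1ccc(-n2cc(C(=O)c3cc(OC)c(OC)c(OC)c3)c(-c3ccccc3)c2)cc1`: 120 nM

Among the measured compounds shown here, in a functional assay on MCF7 cells (Homo sapiens) for cytotoxicity, read by MTT assay, with a stated time of 96 h (on this read-out lower numbers stand for stronger inhibition and higher numbers for weaker inhibition), compound 2 stands level with compound 1 , the only other compound measured, as the two values lie within the scatter of each other. Compound 3 `COc1cc(C(=O)c2cn(-c3cc(OC)c(OC)c(OC)c3)cc2-c2ccccc2)cc(OC)c1OC` is still unmeasured and differs from compound 2 as follows: 3,4,5-trimethoxyphenyl in place of 4-methoxyphenyl on an aromatic nitrogen. For the measured compounds named here, one measured step bears on this change, a swap on the same aromatic nitrogen: a 1.3-fold lower number from compound 1 to compound 2 (0.10 log units; within the scatter). Going by the values given here, with only that small step as a guide, no change beyond the scatter is expected in this assay. The expected step is a 1.5-fold higher number from compound 2 to compound 3 (0.18 log units; within the scatter). For compound 3 the estimate is 180 nM, with an expected range from 50 nM to 650 nM.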

Compound 3, half-maximal inhibitory concentration: > 5000 nM
Compound 3 ended at the assay's limit; the forecaster's own chance of this, stated with the estimate: 3%; middle value at least 27-fold (1.44 log units) away from the limit.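

Compound 3 stands at a limit of this assay, not at a number: the limit of > 5000 nM in this assay, at which 1 of the 3 values shown sits.

The 3-chlorophenyl and 4-methoxyphenyl groups on the aromatic nitrogen stood level, but 3,4,5-trimethoxyphenyl there gives an at least 41-fold higher number from compound 2 to compound 3 (1.61 log units; beyond the scatter) and an at least 33-fold higher number from compound 1 to compound 3 (1.52 log units; beyond the scatter). This position therefore does not accept every substituted phenyl group, which the earlier pair gave no sign of.

The compounds shown leave open whether one further methoxy group on this phenyl ring would already produce so large a step. Going by these compounds, how an amine or a carboxylic acid on that ring would read also remains open.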